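Removing the cyclopentyl from compound 2

The source may hold more compounds than are shown below. What is called first, only, known or untested is meant among the compounds shown, and "the series" means these compounds.

In a functional assay on K562 cells (Homo sapiens) for antiproliferative activity, read by CCK-8 assay, with a stated time of 72 h (a higher number here means a weaker inhibitor of growth, a lower number a stronger inhibitor of growth), compound 1 `CCC1C(=O)N(C)c2cnc(-n3ccc4cc(C(=O)NCC(C)C)ccc43)nc2N1c1ccn(C)n1` gives 5600 nM, and compound 2 `CCC1C(=O)N(C)c2cnc(-n3ccc4cc(C(=O)NC5CCCC5)ccc43)nc2N1c1ccn(C)n1` gives 31300 nM, the higher of the two numbers. Compound 3 `CCC1C(=O)N(C)c2cnc(-n3ccc4cc(C(N)=O)ccc43)nc2N1c1ccn(C)n1` differs from compound 2 in one place: hydrogen in place of cyclopentyl on an amide-type nitrogen. Going by the values given here, only one measured step bears on this change: a 5.6-fold higher number from compound 1 to compound 2 (0.75 log units; beyond the scatter), a modest step at that same nitrogen. With so little to go on, a similar or somewhat smaller step toward a lower number is expected, and the direction remains uncertain. The expected step is a 2.6-fold lower number from compound 2 to compound 3 (0.42 log units; beyond the scatter). For compound 3, the estimated value is 12000 nM, within an expected range of 3000 nM to 40000 nM.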

Compound 3, concentration for 50% growth inhibition: 31300 nM
For compound 3 the middle estimate is 2.6-fold (0.42 log units) below the measured one, and the stated range covers the measured number.
By their numbers in this assay, from the lowest: compound 1; then compounds 2 and 3 (each within the scatter of the next).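

In this assay, hydrogen in place of cyclopentyl on the amide-type nitrogen gives no change at the digits printed from compound 2 to compound 3 (within the scatter), so the cyclopentyl shows no measurable effect compared with the plain carbamoyl. Hydrogen in place of isobutyl gives a 5.6-fold higher number from compound 1 to compound 3 (0.75 log units; beyond the scatter), so among these three compounds only the isobutyl amide stands apart, and a substituent on this nitrogen is not enough by itself to lower the number. Nothing available explains why isobutyl and cyclopentyl differ here. On these data alone, whether a straight butyl chain or a benzyl group would behave like isobutyl or like cyclopentyl remains open.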